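The source may report more compounds than this note shows. Statements on the series, on what has been measured and on what is new or still open speak of the compounds shown alone.

Compound 1, `O=C(NC/C=C1\CCCc2cnn(-c3ccc(C(F)(F)F)cc3)c21)NS(=O)(=O)c1cc(Cl)c(Cl)s1`, is the stronger of the two measured compounds in a functional assay on CHO-K1 cells for antagonist activity at prostaglandin E2 receptor EP3 subtype (Homo sapiens), read by TR-FRET and cAMP accumulation, with a stated time of 30 min (a lower number here means a stronger inhibitor, a higher number a weaker inhibitor), where compound 1 gives 4 nM. Compound 2, `O=C(NS(=O)(=O)c1ccc(Cl)cc1)OC/C=C1\CCCc2cnn(Cc3ccc(Cl)cc3Cl)c21`, gives 92 nM in this assay, and that gap lies beyond the scatter. Compound 3, `CS(=O)(=O)c1ccc(-n2ncc3c2/C(=C/CNC(=O)NS(=O)(=O)c2cc(Cl)c(Cl)s2)CCC3)cc1`, differs from compound 1 in one place: methylsulfonyl in place of trifluoromethyl on an aromatic carbon. Within the data shown here, no measured pair shows this exchange, so its effect is unknown here; a modest weakening, somewhat beyond the scatter, is expected, and the expected step reads a 2.5-fold higher number from compound 1 to compound 3 (0.40 log units; beyond the scatter). Compound 3 is thus estimated to give about 10 nM in this assay, within a range from 3 nM to 40 nM.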

Compound 3, half-maximal inhibitory concentration: 30 nM
The estimate for compound 3 lay 3.0-fold (0.48 log units) below the measured number; low and high end bracket the measured number.
By their numbers in this assay, from the lowest: compound 1; then compound 3; then compound 2.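

In this assay, methylsulfonyl in place of trifluoromethyl on this aromatic carbon gives a 7.5-fold higher number from compound 1 to compound 3 (0.88 log units; beyond the scatter), so the group at this position clearly affects the number. The heavy-atom count stays the same, while methylsulfonyl brings hydrogen-bond acceptors that trifluoromethyl lacks, so the heavy-atom count alone does not set the number here. Nothing measured here explains the step. On these data alone, whether a nitrile or an amine at this position would give a number nearer compound 1 or compound 3 remains open. So does whether this exchange would give a similar step on another core.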